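A halogen exchange on the sulfonyl-bound aryl group

The source may hold more compounds than are shown below. What is called first, only, known or untested is meant among the compounds shown, and "the series" means these compounds.

Among the compounds with values here, in an ADME assay on HEK-293T cells (Homo sapiens) for inhibition, read by CCK-8 assay, with a stated time of 48 h, tested at 20 uM (a higher number here means more inhibition of growth at the concentration tested, a lower number less inhibition of growth), three compounds have numbers so far. Compound 1 (`N#C/C(=C\c1ccccc1OS(=O)(=O)c1ccc(F)cc1)C(=O)Nc1nnc(Cc2cccc3ccccc23)s1`) gives 15% on this read-out, compound 2 (`N#C/C(=C\c1ccccc1OS(=O)(=O)c1ccccc1[N+](=O)[O-])C(=O)Nc1nnc(Cc2ccc(Cl)cc2)s1`) gives 20% on the same read-out, and compound 3 (`N#C/C(=C\c1ccccc1OS(=O)(=O)c1ccc(Cl)cc1)C(=O)Nc1nnc(Cc2ccc(Cl)cc2)s1`) gives 14% on it too. Compound 3 therefore stands within the scatter of both other compounds, and the three numbers cannot be ranked.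

Compound 4 (`N#C/C(=C\c1ccccc1OS(=O)(=O)c1ccc(F)cc1)C(=O)Nc1nnc(Cc2ccc(Cl)cc2)s1`) has not yet been measured. It differs from compound 3 by a single exchange (fluoro in place of chloro on an aromatic carbon) of fluoro in place of chloro on an aromatic carbon, para to a large group, which turns 4-chlorophenyl into 4-fluorophenyl.

Within the data shown here, the one measured step on this part of the molecule is a number 6 percentage points lower from compound 2 to compound 3 (within the scatter) for 4-chlorophenyl in place of 2-nitrophenyl on a sulfonyl sulfur. Among the measured compounds shown here, compound 1 already carries the 4-fluorophenyl group, with a different group elsewhere, and gives 15% in this series, but no measured pair isolates fluoro against chloro. On the strength of a number 6 percentage points lower from compound 2 to compound 3 (within the scatter) no step beyond the scatter is expected in this assay here. The expected change is a number 1 percentage points higher from compound 3 to compound 4 (within the scatter) as an estimate. For compound 4 the estimated value is 15% with an expected range from 6% to 25% as the likely span.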

Compound 4, percent growth inhibition at one concentration: 14%
Beside the measured number, compound 4's estimate is 1 percentage points above it; measured number inside the range.
By their numbers in this assay, from the lowest: compounds 3, 4, 1 and 2 (each within the scatter of the next).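

With fluoro in place of chloro on an aromatic carbon, para to a large group, the halogen exchange on the sulfonyl-bound aryl group now has a matched pair of its own, and in this assay it gives no change at the digits printed from compound 3 to compound 4 (within the scatter). Against 2-nitrophenyl on the sulfonyl sulfur, 4-fluorophenyl gives a number 6 percentage points lower from compound 2 to compound 4 (within the scatter), so this direct comparison also stays inside the scatter, as the 4-chlorophenyl comparison did. The first matched pair at the other site of variation, with 4-chlorophenyl in place of naphthalen-1-yl on a saturated chain carbon bound to an aromatic carbon, gives a number 1 percentage points lower from compound 1 to compound 4 (within the scatter), so none of the single exchanges shown at either site separates these compounds in this assay.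

Nothing given here accounts for these numbers. As far as these compounds go, whether an amine or a carboxylic acid on the sulfonyl-bound aryl ring, or a longer chain in place of the saturated chain carbon, would produce a step beyond the scatter remains open, as does how these compounds would behave at any other concentration.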